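The compounds below may be only part of what the source reports. "The series", "measured", "known", "first", "only" and "open" are said of these compounds alone.

Measured in a functional assay on HeLa cells (Homo sapiens) for antiproliferative activity, read by MTT assay, with a stated time of 48 h; a lower number here means a stronger inhibitor, a higher number a weaker inhibitor:
- Compound 1 `Fc1ccc(-c2nn(-c3ccccc3)cc2-c2nc3cc(F)ccc3[nH]2)cc1`: 1570 nM
- Compound 2 `Clc1ccc(-c2nn(-c3ccccc3)cc2-c2nc3ccccc3[nH]2)cc1`: 1650 nM
- Compound 3 `Fc1ccc2[nH]c(-c3cn(-c4ccccc4)nc3-c3ccc(Cl)cc3)nc2c1`: 2770 nM

In this assay compound 3 gives 2770 nM, and it stands level with the other two compounds. There is a 1.8-fold higher number from compound 1 to compound 3 (0.25 log units; within the scatter), and there is a 1.7-fold higher number from compound 2 to compound 3 (0.22 log units; within the scatter). Neither step separates compound 3 from its neighbours.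

Compound 4 `FC(F)(F)c1ccc2[nH]c(-c3cn(-c4ccccc4)nc3-c3ccc(Cl)cc3)nc2c1` keeps the structure of compound 3 except for one group: trifluoromethyl in place of fluoro on an aromatic carbon. This carbon belongs to a six-membered aromatic ring of carbon only, part of a fused or bridged system of two rings. Among the measured compounds shown here, no compound measured so far carries trifluoromethyl, so no step shows this change directly.

The closest evidence is the hydrogen-to-fluoro change on that same carbon, which gave a 1.7-fold higher number from compound 2 to compound 3 (0.22 log units; within the scatter). The chloro-for-fluoro change elsewhere in the molecule gave a 1.8-fold higher number from compound 1 to compound 3 (0.25 log units; within the scatter). Both steps stay within the scatter, so the three compounds offer no basis for a direction, and no shift beyond the scatter is expected in this assay. The expected step is a 1.1-fold lower number from compound 3 to compound 4 (0.03 log units; within the scatter). The estimate for compound 4 is 2600 nM, with an expected range of 1100 nM to 6000 nM.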

Compound 4, half-maximal inhibitory concentration: 4420 nM
Estimate against measurement, compound 4: 1.7-fold (0.23 log units) below; the range from low to high includes it.
By their numbers in this assay, from the lowest: compounds 1, 2, 3 and 4 (each within the scatter of the next, the first and the last beyond it).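

In this assay, replacing fluoro with trifluoromethyl on this aromatic carbon gives a step that stays within the scatter (a 1.6-fold higher number from compound 3 to compound 4 (0.20 log units; within the scatter)), so these two groups cannot be ranked at this position, even though the entering group brings four heavy atoms where the leaving group has one. The comparison with hydrogen on the same carbon is more informative (a 2.7-fold higher number from compound 2 to compound 4 (0.43 log units; beyond the scatter)): it is the first step at this position to pass beyond the scatter, though only modestly, whereas the earlier compounds had shown only a hydrogen-to-fluoro step within it, so the position does respond to substitution, and trifluoromethyl gives the higher number, meaning the weaker inhibitor, relative to hydrogen. Nothing available on these compounds accounts for that step.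

The compounds shown leave open whether any group on this carbon could give a lower number than hydrogen does, since only fluoro and trifluoromethyl are compared with it and neither an amine nor a carboxylic acid appears there. They also leave open whether the step from hydrogen to trifluoromethyl would hold with fluoro in place of chloro elsewhere in the molecule.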